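This account rests on a few compounds, and the source may have more. Where it says the series, first, only, none or still open, it means among the compounds named here.

Working notes on the series. In an assay on CHO cells for displacement of a labelled ligand from 5-hydroxytryptamine receptor 7 (Homo sapiens), read by scintillation counting, with a stated time of 60 min (a higher number here means a weaker inhibitor, a lower number a stronger inhibitor), compound 3 `COc1ccc(/C=C2\NC(=O)N(CCCN3CCN(c4cccc(Cl)c4Cl)CC3)C2=O)cc1OC1CCCC1` gives 380 nM, the highest of the three numbers recorded. In this assay compound 1 `COc1ccc(/C=C2\NC(=O)N(CCCN3CCN(c4ncccn4)CC3)C2=O)cc1OC` gives 74 nM, and compound 2 `COc1ccc(/C=C2\NC(=O)N(CCCN3CCN(c4ccccc4OC)CC3)C2=O)cc1OC1CCCC1` gives 6 nM. The next entry is compound 4 `COc1ccc(/C=C2\NC(=O)N(CCCN3CCN(c4ncccn4)CC3)C2=O)cc1OC1CCCC1`, which differs from compound 3 by pyrimidin-2-yl in place of 2,3-dichlorophenyl on an amine nitrogen in a ring. Going by the values given here, the one measured step that bears on this position is a 63-fold higher number from compound 2 to compound 3 (1.80 log units; beyond the scatter), showing that exchange of the group on that ring nitrogen can move this assay by a large amount. Among the compounds with values here, compound 1 already carries the entering pyrimidin-2-yl group, and its value in this assay lies well under that of compound 3, though the two also differ elsewhere and no step is recorded for that pair. A sizeable drop is therefore expected, namely a 7.6-fold lower number from compound 3 to compound 4 (0.88 log units; beyond the scatter). In this assay compound 4 is estimated at 50 nM, with a range of 15 nM to 200 nM.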

Compound 4, inhibition constant: > 1000 nM
Compound 4: a limit, no number (the forecaster's own chance of this, stated with the estimate: 2%); at least 20-fold (1.30 log units) between middle value and limit.
By their numbers in this assay, from the lowest: compound 2; then compound 1; then compound 3. At a limit, above all of these: compound 4.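

In this assay compound 4 gives a limit and not a number: the limit of > 1000 nM in this assay, at which 1 of the 4 values shown sits. With cyclopentyl held on the oxygen, pyrimidin-2-yl on the ring nitrogen reads weaker than either substituted phenyl group, with an at least 2.6-fold higher number from compound 3 to compound 4 (0.42 log units; beyond the scatter) and an at least 160-fold higher number from compound 2 to compound 4 (2.22 log units; beyond the scatter). Going by these compounds alone, the group on the oxygen also matters with pyrimidin-2-yl held in place, a change the earlier compounds did not isolate, with an at least 13-fold higher number from compound 1 to compound 4 (1.13 log units; beyond the scatter). Still open, as far as these compounds go, is whether cyclopentyl in place of methyl moves the number the same way with 2-methoxyphenyl on the ring nitrogen. Also open, from the compounds shown here alone, is how pyridin-2-yl or unsubstituted phenyl would read at that nitrogen.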